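The source may hold more compounds than are shown below. What is called first, only, known or untested is meant among the compounds shown, and "the series" means these compounds.

Of the compounds shown here, three built on one shared core have been tested in a functional assay on T47D cells (Homo sapiens) for inhibition; on this read-out higher numbers stand for weaker inhibition and lower numbers for stronger inhibition. Compound 1 has the structure `Oc1ccccc1-c1cc(-c2ccccc2C(F)(F)F)cc(-c2ccccc2O)n1`, compound 2 the structure `Oc1ccccc1-c1cc(-c2cccc(C(F)(F)F)c2)cc(-c2ccccc2O)n1`, and compound 3 the structure `Oc1cccc(-c2cc(-c3ccccc3C(F)(F)F)cc(-c3ccccc3O)n2)c1`. In this assay compound 1 gives 22500 nM. For compound 2 the result is only a limit of the assay, > 50000 nM, and not a number. Compound 3 gives 5680 nM, the lowest number among the measured values.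

Two single changes connect these compounds. Swapping one group, (3-hydroxyphenyl in place of 2-hydroxyphenyl on an aromatic carbon), brings a 4.0-fold lower number from compound 1 to compound 3 (0.60 log units; beyond the scatter). Swapping a different group, (3-(trifluoromethyl)phenyl in place of 2-(trifluoromethyl)phenyl on an aromatic carbon), brings an at least 2.2-fold higher number from compound 1 to compound 2 (0.34 log units; beyond the scatter); this step can only be given as a lower bound because of the limit of > 50000 nM in this assay, at which 1 of the 3 values shown sits.

Compound 4, with the structure `Oc1cccc(-c2cc(-c3cccc(C(F)(F)F)c3)cc(-c3ccccc3O)n2)c1`, has not yet been measured. It differs from compound 3 in the same way that compound 2 differs from compound 1: 3-(trifluoromethyl)phenyl in place of 2-(trifluoromethyl)phenyl on an aromatic carbon. The surroundings are not quite identical, though. In compound 1 the changed group sits meta to two 2-hydroxyphenyl groups, whereas in compound 3 it sits meta to a 2-hydroxyphenyl group and meta to a 3-hydroxyphenyl group, so this is the same kind of change rather than the same change.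

Resting on the step from compound 1 to compound 2, the move from compound 3 to compound 4 is expected to be a 3.5-fold higher number from compound 3 to compound 4 (0.55 log units; beyond the scatter). Compound 4 is therefore estimated at 20000 nM in this assay, most likely somewhere between 7000 nM and 55000 nM.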

Compound 4, half-maximal inhibitory concentration: 6340 nM
Compound 4: the middle estimate sits 3.2-fold (0.50 log units) above what was measured; the measured number lies below the stated range.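

With a 3-hydroxyphenyl group on the shared core, 3-(trifluoromethyl)phenyl in place of 2-(trifluoromethyl)phenyl gives a 1.1-fold higher number from compound 3 to compound 4 (0.05 log units; within the scatter) in this assay, so on this core the swap shows no real effect on the read-out. The result for compound 2, > 50000 nM, is a limit of the assay and not a number, so the data show neither that the swap carries over between the two cores with the same size nor that its size depends on the core: the same change on two cores in this assay, an at least 2.2-fold higher number (0.34 log units; beyond the scatter) from compound 1 to compound 2 and a 1.1-fold higher number (0.05 log units; within the scatter) from compound 3 to compound 4; the limit leaves it open whether they differ The other swap, 3-hydroxyphenyl in place of 2-hydroxyphenyl, gives an at least 7.8-fold lower number from compound 2 to compound 4 (0.89 log units; beyond the scatter), so in these four compounds its direction holds on both cores, while its exact size stays unsettled: the same change on two cores in this assay, a 4.0-fold lower number (0.60 log units; beyond the scatter) from compound 1 to compound 3 and an at least 7.8-fold lower number (0.89 log units; beyond the scatter) from compound 2 to compound 4; the limit leaves it open whether they differ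

As far as these compounds go, whether these trends would hold with an amine or a carboxylic acid in place of the hydroxyl group, or with a nitrile in place of the trifluoromethyl group, remains open. From the compounds shown here alone, it is also open what would happen if the remaining 2-hydroxyphenyl group of compound 3 or compound 4 became a second 3-hydroxyphenyl group.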